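A few compounds are considered here, and "the series" means these few. Any claim that something is new, unique, unknown or untested is made for them only; others in the source may bear on it.

Compound 1 `CCCOC(=O)C1=C(C)NC(=O)NC1c1ccoc1`: 50%
Compound 2 `CCNC(=O)C1=C(C)NC(=O)NC1c1ccoc1`: 1%

Going by the values given here, in an assay on membranes from CHO cells for displacement of a labelled ligand from adenosine receptor A1 (Homo sapiens), read by scintillation counting, with a stated time of 60 min, tested at 1 uM (a higher number here means more inhibition at the concentration tested (going by the name of the read-out), a lower number less inhibition), compound 2 stands lowest of the two numbers, with compound 1 as its nearest neighbour, the only measured step being a number 49 percentage points lower from compound 1 to compound 2 (beyond the scatter). Compound 3 `CCN(CC)C(=O)C1=C(C)NC(=O)NC1c1ccoc1` differs from compound 2 by ethyl in place of hydrogen on an amide-type nitrogen. Among the compounds with values here, the measured step exchanged propoxy for ethylamino on the carbonyl carbon and does not bear on an ethyl entering at the amide-type nitrogen, so no measured step speaks to this change. One therefore expects no step beyond the scatter in this assay, an estimated a number 4 percentage points higher from compound 2 to compound 3 (within the scatter). Compound 3 is expected to give 5%, within a range from -10% to 25%.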

Compound 3, a percentage reported as inhibition, at one concentration (the size of the read-out at that concentration, not a potency): 15%
Beside the measured number, compound 3's estimate is 10 percentage points below it, and the stated range covers the measured number.
By their numbers in this assay, from the lowest: compound 2; then compound 3; then compound 1.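

In this assay, the amide-type nitrogen is not indifferent to substitution: ethyl in place of hydrogen gives a number 14 percentage points higher from compound 2 to compound 3 (beyond the scatter) at this position. Diethylamino in place of propoxy on the carbonyl carbon still leaves a number 35 percentage points lower from compound 1 to compound 3 (beyond the scatter) in this series, so the added ethyl restores only part of the number lost on leaving the propyl ester. No evidence given here explains either step. Open, going by these compounds, is whether a propyl chain on this nitrogen would raise the number further, and whether a cyclic amine such as piperidine on the carbonyl carbon would come closer to compound 1.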